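A few compounds are considered here, and "the series" means these few. Any claim that something is new, unique, unknown or untested is made for them only; others in the source may bear on it.

Working notes on the series in an assay on isolated protein for inhibition of kinesin heavy chain isoform 5A (Homo sapiens); on this read-out lower numbers stand for stronger inhibition and higher numbers for weaker inhibition.

Three compounds share the core and carry a trifluoromethylbenzyl group; all three so far return only a limit. Compound 1 `COc1ccc(Nc2nc3cc(C(=O)Nc4ccccc4OC)ccc3n2Cc2ccccc2C(F)(F)F)cc1` bears a (2-methoxyphenyl)carbamoyl group and a methoxyphenyl amine. In this assay compound 1 gives > 50000 nM, which is a limit of the assay and not a number. Compound 2 `CNC(=O)c1ccc2c(c1)nc(Nc1ccc(S(N)(=O)=O)cc1)n2Cc1ccccc1C(F)(F)F` carries a methylcarbamoyl group and a sulfonamide aniline. In this assay compound 2 gives > 50000 nM, again a limit. Compound 3 `NS(=O)(=O)c1ccc(Nc2nc3cc(C(=O)N4CCCC4)ccc3n2Cc2ccccc2C(F)(F)F)cc1` keeps the sulfonamide aniline with a (pyrrolidin-1-yl)carbonyl group. In this assay compound 3 gives > 50000 nM, also a limit. The step that the two limits leave unreadable from compound 2 to compound 3 is therefore unreadable, and compound 3 stands where every value in the set stands, at the limit of > 50000 nM in this assay, at which 3 of the 3 values shown sit.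

Compound 4 `COc1ccccc1NC(=O)c1ccc2c(c1)nc(Nc1ccc(S(N)(=O)=O)cc1)n2Cc1ccccc1C(F)(F)F` is the next change: (2-methoxyphenyl)amino in place of pyrrolidin-1-yl on a carbonyl carbon. The step from compound 3 pairs the amide of compound 1 with the aniline of compound 3. Among the measured compounds shown here, no measured step gives a readable size, and the amide of compound 1 and the aniline of compound 3 each sit at the limit. Compound 4 is therefore expected to change by a number no higher from compound 3 to compound 4 (the limit leaves the size open), within the scatter. Compound 4 is estimated at 50000 nM, between 20000 nM and 200000 nM.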

Compound 4, half-maximal inhibitory concentration: > 50000 nM
Compound 4 ended at the assay's limit; the forecaster's own chance of this, stated with the estimate: 85%; the middle value sits exactly at the limit.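

Compound 4 sits at a limit in this assay, as do compound 1, compound 2 and compound 3, so none of the steps linking compound 4 to them can be read: the limit of > 50000 nM in this assay, at which 4 of the 4 values shown sit.

The compounds shown leave open how large any of these changes is, and which groups on the shared core, if any, would give a readable value.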